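The source may report more compounds than this note shows. Statements on the series, on what has been measured and on what is new or still open speak of the compounds shown alone.

Compound 1, whose structure is `C=C(Br)C(=O)Nc1cccc(/C=C/C(=O)Nc2ccccc2)c1`, is the starting point of this small series. In a functional assay on SEM cells (Homo sapiens) for inhibition, read by MTT assay, with a stated time of 72 h (a lower number here means a stronger inhibitor, a higher number a weaker inhibitor), compound 1 gives 1100 nM. Compound 2, with the structure `C=C(Br)C(=O)Nc1cccc(/C=C/C(=O)Nc2ccc(OC)cc2)c1`, differs from it in a single place: the change is methoxy in place of hydrogen on an aromatic carbon, and the step it made is a 16-fold lower number from compound 1 to compound 2 (1.20 log units; beyond the scatter). In this assay compound 2 gives 70 nM. Compound 3 has the structure `C=C(Br)C(=O)Nc1cccc(/C=C/C(=O)Nc2cc(OC)cc(OC)c2)c1`; how its core differs from the core of compound 1 is not broken down here. In this assay compound 3 gives 40 nM, which lies within the usual scatter of the value for compound 2, so no order between compound 2 and compound 3 can be claimed.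

Compound 4, whose structure is `C=C(Br)C(=O)Nc1cccc(/C=C/C(=O)Nc2cc(OC)c(OC)c(OC)c2)c1`, has not yet been measured. It differs from compound 3 in one place: the change is methoxy in place of hydrogen on an aromatic carbon. Among the compounds with values here, this is the same kind of change as the one from compound 1 to compound 2, but the surroundings differ: in compound 4 the new group sits ortho to two methoxy groups (2 heavy atoms each) as well as para to a large group, whereas in compound 2 it sits only para to a large group. The earlier step was large, but the second methoxy, from compound 2 to compound 3, brought a change within the scatter, so a third is expected to bring little more. The expected step is a 1.1-fold lower number from compound 3 to compound 4 (0.06 log units; within the scatter), and compound 4 is estimated to give 35 nM, roughly between 10 nM and 120 nM.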

Compound 4, half-maximal inhibitory concentration: 18 nM
For compound 4 the middle estimate is 1.9-fold (0.29 log units) above the measured one; the range from low to high includes it.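

In this assay, the change of methoxy in place of hydrogen gave a 2.2-fold lower number from compound 3 to compound 4 (0.35 log units; beyond the scatter), so it pointed the same way as it did on the core of compound 1. The size of the step did not carry over, however, and the gap between the two steps is larger than measurement scatter alone would explain: the same change on two cores in this assay, a 16-fold lower number (1.20 log units; beyond the scatter) from compound 1 to compound 2 and a 2.2-fold lower number (0.35 log units; beyond the scatter) from compound 3 to compound 4, 7.1-fold (0.85 log units) apart, beyond the scatter of two such steps These two steps show that the direction held in both cases, but they do not explain why the sizes differ, and they give no rule for predicting the size of the step on another core, since the surroundings of the new group also differ, with compound 4 carrying it ortho to two methoxy groups.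

The aromatic ring that changes here carries only hydrogen or methoxy in the compounds shown, so it remains open whether another group there, such as a hydroxyl, an amine or a fluorine atom, would give a similar number. All four compounds also keep the same bromine-bearing amide, which leaves open what a chlorine atom in place of that bromine would do to the number.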